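The source may report more compounds than this note shows. Statements on the series, on what has been measured and on what is new or still open speak of the compounds shown alone.

Working notes on the series. Compound 1 `COc1cc(CSc2cc(Cl)c(-c3nnc(-c4ccc(Cl)cc4)s3)cc2S(=O)(=O)NC(=N)NO)cc(OC)c1OC` gives 8130 nM in a functional assay on Hs-578T cells (Homo sapiens); a lower number here means a stronger inhibitor of growth, a higher number a weaker inhibitor of growth. Compound 2 `N=C(NO)NS(=O)(=O)c1cc(-c2nnc(-c3ccc(Cl)cc3)s2)c(Cl)cc1SCc1ccccc1` gives 2510 nM in this assay. Among the measured compounds shown here, of the two numbers known, compound 1 stands highest; the only measured step, a 3.2-fold lower number from compound 1 to compound 2 (0.51 log units; beyond the scatter), rests on phenyl in place of 3,4,5-trimethoxyphenyl on a saturated chain carbon bound to a sulfur, so it concerns the thioether-linked arm and not the heteroaryl group.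

Compound 3 `COc1cc(CSc2cc(Cl)c(-c3nc(-c4ccccc4)no3)cc2S(=O)(=O)NC(=N)NO)cc(OC)c1OC` is not yet measured. It differs from compound 1 by 3-phenyl-1,2,4-oxadiazol-5-yl in place of 5-(4-chlorophenyl)-1,3,4-thiadiazol-2-yl on an aromatic carbon. For the measured compounds named here, no measured pair changes this heteroaryl group, and the step from compound 1 to compound 2 sits elsewhere on the core; it therefore gives no direction for the present change. The expectation is accordingly anchored on compound 1 itself, with a step of a 1.0-fold lower number from compound 1 to compound 3 (0.01 log units; within the scatter), which is not expected to exceed the scatter in either direction, while the absence of any bearing step widens the range. For compound 3 the estimated value in this assay is 8000 nM, within 2000 nM to 32000 nM.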

Compound 3, concentration for 50% growth inhibition: 7410 nM
Compound 3: middle estimate off by 1.1-fold (0.03 log units), on the high side, within the range that was stated.
By their numbers in this assay, from the lowest: compound 2; then compounds 3 and 1 (each within the scatter of the next).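

Among the compounds shown here, replacing 5-(4-chlorophenyl)-1,3,4-thiadiazol-2-yl with 3-phenyl-1,2,4-oxadiazol-5-yl on the aromatic carbon gives a 1.1-fold lower number from compound 1 to compound 3 (0.04 log units; within the scatter) in this assay, the first reading at this position, which the earlier step on the thioether-linked arm could not supply. With the 3,4,5-trimethoxyphenyl arm held constant, the two heteroaryl groups cannot be told apart in this read-out, even though the exchange alters both the five-membered ring and the chlorine on the outer ring, so the step cannot separate those two alterations. Nothing at hand offers an explanation for this result.

The compounds shown leave open whether the same heteroaryl exchange would read alike with the phenyl arm of compound 2, whose number is the lowest of the three, and whether the chlorine or the change of five-membered ring would show any separate effect. Also open, as far as these compounds go, is how a group of a different kind at this position, such as a carboxylic acid or an amine on the outer phenyl ring, would read in this assay.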